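The compounds below may be only part of what the source reports. "The series", "measured", "known", "first", "only" and "open" are said of these compounds alone.

Compound 1 `Nc1ncnc2c1c(-c1cnc3[nH]ccc3c1)nn2CCCCC(=O)NO` and compound 2 `Nc1ncnc2c1c(-c1cnc3[nH]ccc3c1)nn2CCCCCC(=O)NO` share one core and differ only at the end of the chain that carries the hydroxamic acid. In a functional assay on HepG2 cells (Homo sapiens) for inhibition, read by MTT assay, with a stated time of 72 h (on this read-out higher numbers stand for weaker inhibition and lower numbers for stronger inhibition), compound 1 gives 36700 nM, while compound 2 gives 12900 nM. The change between them is (hydroxycarbamoyl)methyl in place of hydroxycarbamoyl on a saturated chain carbon, four bonds along the chain from an aromatic nitrogen. That single change produced a 2.8-fold lower number from compound 1 to compound 2 (0.45 log units; beyond the scatter), a clear move towards stronger inhibition of the cells.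

Compound 3 `Nc1nc2cc(-c3nn(CCCCC(=O)NO)c4ncnc(N)c34)ccc2o1` is built on a different core; the difference between the two cores is not broken down here. In this assay compound 3 gives 2100 nM, the lowest of the three measured numbers, and its distance from both compound 2 and compound 1 lies beyond the usual scatter.

Compound 4 `Nc1nc2cc(-c3nn(CCCCCC(=O)NO)c4ncnc(N)c34)ccc2o1` has not yet been measured. It stands to compound 3 exactly as compound 2 stands to compound 1: (hydroxycarbamoyl)methyl in place of hydroxycarbamoyl on a saturated chain carbon, four bonds along the chain from an aromatic nitrogen. The groups that leave and enter and the place on the chain match word for word, so this is the same change carried over to the second core.

Because the same change gave a 2.8-fold lower number from compound 1 to compound 2 (0.45 log units; beyond the scatter) on the first core, a step of a 2.6-fold lower number from compound 3 to compound 4 (0.42 log units; beyond the scatter) is expected here as well. This rests on one earlier example only, and the cores differ in a way that is not broken down, so the range is kept wide. Compound 4 is therefore estimated at 800 nM in this assay, expected to fall between 300 nM and 2200 nM.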

Compound 4, half-maximal inhibitory concentration: 1990 nM
The estimate for compound 4 lay 2.5-fold (0.40 log units) below the measured number, and the stated range covers the measured number.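

Read in this assay, a 1.1-fold lower number from compound 3 to compound 4 (0.02 log units; within the scatter) is the step that the added chain carbon gives on the second core, and this read-out does not separate the two chain lengths there. Among the compounds shown here, the same change on the first core gave a step beyond the scatter, so its size did not carry over from one core to the other: the same change on two cores in this assay, a 2.8-fold lower number (0.45 log units; beyond the scatter) from compound 1 to compound 2 and a 1.1-fold lower number (0.02 log units; within the scatter) from compound 3 to compound 4, 2.7-fold (0.43 log units) apart, beyond the scatter of two such steps. This shows that, across these two pairs, the size of the step depends on which core carries the chain, but it gives no reason for the difference, says nothing about a third core, and two pairs are too few to make a rule.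

The compounds shown leave open what a longer chain than 4-(hydroxycarbamoyl)butyl would give on either core, and whether the first core would keep gaining from it while the second stayed level. They also leave open what a carboxylic acid in place of the hydroxycarbamoyl end would give on these chains, and so how much of the read-out depends on that end group rather than on the chain or the core.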